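The compounds below may be only part of what the source reports. "The series", "measured", "known", "first", "only" and "open" are said of these compounds alone.

- compound 1 `COc1ccc(/C=C/C(=O)c2ccccc2-c2ccc(F)cc2)cc1` at 140 nM
- compound 2 `COc1ccc(/C=C/C(=O)c2ccccc2-c2ccc(F)cc2)cc1B(O)O` at 82 nM
- compound 3 `COc1ccc(/C=C/C(=O)c2ccccc2-c2cccc(F)c2)cc1` not yet measured

In a functional assay on A549 cells (Homo sapiens) for antiproliferative activity, read by sulforhodamine B assay, with a stated time of 48 h (a lower number here means a stronger inhibitor, a higher number a weaker inhibitor), compound 1 stands within the scatter of compound 2. Going by the values given here, the one measured step (a 1.7-fold lower number from compound 1 to compound 2 (0.23 log units; within the scatter)) adds a group at a different place, so it bears only weakly on the next change. Compound 3 carries 3-fluorophenyl in place of 4-fluorophenyl on an aromatic carbon, ortho to a large group (3-fluorophenyl in place of 4-fluorophenyl on an aromatic carbon). Among the compounds with values here, no measured step covers this exchange. Going by the small size of the step to compound 2 (a 1.7-fold lower number from compound 1 to compound 2 (0.23 log units; within the scatter)), no step beyond the scatter is expected in this assay and no direction is favoured. The estimated step (a 1.1-fold higher number from compound 1 to compound 3 (0.03 log units; within the scatter)) is correspondingly small. For compound 3 the expected value is 150 nM (estimated range 55 nM to 420 nM).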

Compound 3, half-maximal inhibitory concentration: 280 nM
Estimate against measurement, compound 3: 1.9-fold (0.27 log units) below, within the range that was stated.
By their numbers in this assay, from the lowest: compounds 2, 1 and 3 (each within the scatter of the next, the first and the last beyond it).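

Going by these compounds alone, this is the first measured change on the fluorophenyl ring itself: 3-fluorophenyl in place of 4-fluorophenyl, ortho to a large group, gives a 2.0-fold higher number from compound 1 to compound 3 (0.30 log units; within the scatter) in this assay. The fluorine can therefore take either of these two placings on this ring without a step beyond the scatter in this assay. No measurement available here accounts for the size of this step.

Still open, as far as these compounds go, is how an amine or a carboxylic acid in place of the fluorine would read here. Also open, from the compounds shown here alone, is whether the group added in compound 2 would read the same alongside 3-fluorophenyl.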